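Compound 3 to compound 4: trimming the long selenium-bearing group

The source may report more compounds than this note shows. Statements on the series, on what has been measured and on what is new or still open speak of the compounds shown alone.

Going by the values given here, in a functional assay on HCT-116 cells (Homo sapiens) for inhibition, read by MTT assay, with a stated time of 48 h (a higher number here means a weaker inhibitor, a lower number a stronger inhibitor), compound 3 `COc1ccc(N(C)c2nc(C)nc3ccccc23)cc1C(=O)OCCCC[Se]C#N` gives 662 nM as the middle of the three numbers measured so far. Compound 1 `COc1ccc(N(C)c2nc(C)nc3ccccc23)cc1OCCCCCC[Se]C#N` stands higher (6180 nM) and compound 2 `COc1ccc(N(C)c2nc(C)nc3ccccc23)cc1[Se]C` stands lower (28 nM). Compound 4 `COc1ccc(N(C)c2nc(C)nc3ccccc23)cc1[Se]C#N` awaits measurement. Its structural change from compound 3 is a group of 3 heavy atoms (1 carbon, 1 nitrogen, 1 selenium; no ring) in place of a group of 10 heavy atoms (6 carbon, 1 nitrogen, 2 oxygen, 1 selenium; no ring), on an aromatic carbon and the place is ortho to a methoxy group (2 heavy atoms).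

Among the compounds with values here, two measured steps bear most directly on this change. Each replaces a group of 10 heavy atoms with a group of 2 heavy atoms, and the reverse of that replacement appears in a 24-fold higher number from compound 2 to compound 3 (1.37 log units; beyond the scatter) while the forward form appears in a 220-fold lower number from compound 1 to compound 2 (2.34 log units; beyond the scatter) and both are large. The group entering compound 4 has 3 heavy atoms and matches no measured group, so the transfer is uncertain. A large step to a lower number is expected in this assay but with compound 4 probably not fully matching compound 2. The expected step is an 11-fold lower number from compound 3 to compound 4 (1.04 log units; beyond the scatter) as estimated here. For compound 4 the estimated value is 60 nM within an expected range from 12 nM to 300 nM on this read-out.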

Compound 4, half-maximal inhibitory concentration: 34 nM
The estimate for compound 4 lay 1.8-fold (0.25 log units) above the measured number, within the range that was stated.
By their numbers in this assay, from the lowest: compounds 2 and 4 (each within the scatter of the next); then compound 3; then compound 1.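

In this assay the group of 3 heavy atoms on this aromatic carbon, ortho to a methoxy group, gives a 19-fold lower number from compound 3 to compound 4 (1.29 log units; beyond the scatter) and also a 180-fold lower number from compound 1 to compound 4 (2.26 log units; beyond the scatter) so the cyano end on selenium is compatible with a low number once the long groups are gone. Cyano in place of methyl on the selenium gives a 1.2-fold higher number from compound 2 to compound 4 (0.08 log units; within the scatter) and at this position the two selenium groups therefore cannot be told apart on this read-out. Nothing measured here explains these steps.

The compounds shown leave open whether selenium itself is needed, which a sulfur atom in its place would test. They also leave open how an amine or a carboxylic acid on this aromatic carbon would read in this assay on the same core.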